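A few compounds are considered here, and "the series" means these few. Any claim that something is new, unique, unknown or untested is made for them only; others in the source may bear on it.

Among the compounds with values here, compound 1 `c1ccc([C@@H]2C[C@@H]3Cc4ccc5ccccc5c4N2O3)cc1` is the only compound with an actual number in an ADME assay on Vero cells (Chlorocebus sabaeus) for cytotoxicity, read by MTT assay, with a stated time of 72 h; a lower number here means that less compound is tolerated, a higher number that more compound is tolerated: compound 1 gives 72900 nM. Compound 2 `COc1cccc([C@@H]2C[C@@H]3Cc4ccc5ccccc5c4N2O3)c1` differs from it by a methoxy in place of hydrogen on an aromatic carbon. In this assay compound 2 reaches only the limit of > 300000 nM. The step is an at least 4.1-fold higher number from compound 1 to compound 2 (0.61 log units; beyond the scatter), and its true size cannot be pinned down because of the limit of > 300000 nM in this assay, at which 1 of the 2 values shown sits. Compound 3 `O=[N+]([O-])c1ccccc1[C@@H]1C[C@@H]2Cc3ccc4ccccc4c3N1O2` is not yet measured; it differs from compound 1 by nitro in place of hydrogen on an aromatic carbon. Within the data shown here, the methoxy step is the only measured change that resembles this one, and it showed the number rising at least modestly when a group replaced hydrogen on that ring. A nitro is a different group, so the expectation is held loosely: the estimated step is a 1.5-fold higher number from compound 1 to compound 3 (0.18 log units; within the scatter), a small rise that may not exceed the scatter. Compound 3 is therefore expected to give about 110000 nM in this assay, within a range from 40000 nM to 300000 nM.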

Compound 3, half-maximal cytotoxic concentration: 40200 nM
Estimate against measurement, compound 3: 2.7-fold (0.44 log units) above; measured number inside the range.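

With nitro on an aromatic carbon, ortho to a large group, this assay gives a 1.8-fold lower number from compound 1 to compound 3 (0.26 log units; within the scatter), so the two compounds cannot be told apart here. Placing a group on this ring therefore does not always move the number: the earlier change, an at least 4.1-fold higher number from compound 1 to compound 2 (0.61 log units; beyond the scatter), is now a single case, and compound 3 goes against any wider pattern.

As far as these compounds go, compound 2 gives > 300000 nM, which is a limit of the assay and not a number, so the full size of the methoxy step remains unknown. Also open, from the compounds shown here alone, is whether an amine or a carboxylic acid at the place that carries nitro in compound 3 would give a step beyond the scatter from compound 1.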